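The source may report more compounds than this note shows. Statements on the series, on what has been measured and on what is new or still open speak of the compounds shown alone.

Compound 3, with structure `Cc1n[nH]c2ccc(-c3nc4cnc(N5CCN(C)CC5)cn4c3Nc3ccc(F)cc3Br)cc12`, has the highest number of the three measured compounds in a functional assay on MV4-11 cells (Homo sapiens) for inhibition, with a stated time of 120 h, tested at 10 uM (a higher number here means more inhibition at the concentration tested (going by the name of the read-out), a lower number less inhibition), where compound 3 gives 82.4%. Compound 1, `Cc1n[nH]c2ccc(-c3nc4cnc(N5CCN(C)CC5)cn4c3Nc3cccc(F)c3)cc12`, gives 18.5% in this assay, and compound 2, `Cc1n[nH]c2ccc(-c3nc4cnc(N5CCN(C)CC5)cn4c3Nc3ccccc3)cc12`, gives 0%. The unmeasured compound 4 has structure `Cc1n[nH]c2ccc(-c3nc4cnc(N5CCN(C)CC5)cn4c3Nc3cc(Cl)ccc3Cl)cc12`. Its change from compound 3 is 2,5-dichlorophenyl in place of 2-bromo-4-fluorophenyl on a nitrogen on an aromatic ring. For the measured compounds named here, two measured steps bear on this change, since both alter the same phenyl group on the same nitrogen: a number 63.9 percentage points higher from compound 1 to compound 3 (beyond the scatter) and a number 82.4 percentage points higher from compound 2 to compound 3 (beyond the scatter). Both show that moving from a phenyl carrying no halogen or one fluorine to the 2-bromo-4-fluorophenyl group raised inhibition by a large amount. Compound 4 keeps a phenyl with two halogens, so the expected step of a number 17.4 percentage points lower from compound 3 to compound 4 (beyond the scatter) is a modest drop, with no clear reason in the data for a large change in either direction. The estimated inhibition for compound 4 is 65%, expected to fall between 30% and 90%.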

Compound 4, a percentage reported as inhibition, at one concentration (the size of the read-out at that concentration, not a potency): 23.8%
Compound 4: the middle estimate sits 41.2 percentage points above what was measured, outside the stated range (below it).
By their numbers in this assay, from the lowest: compound 2; then compounds 1 and 4 (each within the scatter of the next); then compound 3.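

Two halogens on the phenyl do not by themselves give high inhibition in this assay: replacing the 2-bromo-4-fluorophenyl group with 2,5-dichlorophenyl gives a large loss (a number 58.6 percentage points lower from compound 3 to compound 4 (beyond the scatter)), so this position responds to which halogens are present and where they sit, not just to their number. The 2,5-dichlorophenyl group still differs from plain phenyl (a number 23.8 percentage points higher from compound 2 to compound 4 (beyond the scatter)), but it cannot be told apart from 3-fluorophenyl (a number 5.3 percentage points higher from compound 1 to compound 4 (within the scatter)), so among these four compounds only the 2-bromo-4-fluorophenyl group stands out. Nothing measured here gives a reason for these differences.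

The compounds shown do not separate the contribution of the bromine in compound 3 from that of its fluorine. They also leave open how a methyl or methoxy group in place of that bromine would behave.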